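Chloro for Methyl on the Core of Compound 1

A few compounds are considered here, and "the series" means these few. Any claim that something is new, unique, unknown or untested is made for them only; others in the source may bear on it.

Compound 1, `Cc1ccc(NC(=S)NC(=O)c2ccc(OCc3ccc(C(F)(F)F)cc3)cc2)cc1-c1nc2ccccc2[nH]1`, gives 17600 nM in a functional assay on HT-29 cells (Homo sapiens) for inhibition, read by MTT assay, with a stated time of 48 h; a higher number here means a weaker inhibitor, a lower number a stronger inhibitor.
Compound 2, `Cc1ccc(NC(=S)NC(=O)c2ccc(OCc3ccccc3Cl)cc2)cc1-c1nc2ccccc2[nH]1`, gives 23700 nM in this assay.

Compound 1 holds the lowest of the two numbers; its nearest neighbour is compound 2, reached by a 1.3-fold higher number from compound 1 to compound 2 (0.13 log units; within the scatter). Compound 3, `O=C(NC(=S)Nc1ccc(Cl)c(-c2nc3ccccc3[nH]2)c1)c1ccc(OCc2ccc(C(F)(F)F)cc2)cc1`, differs from compound 1 by chloro in place of methyl on an aromatic carbon. Among the measured compounds shown here, the single measured step, a 1.3-fold higher number from compound 1 to compound 2 (0.13 log units; within the scatter), concerns a different part of the molecule and does not bear on this exchange. For the measured compounds named here, no measured pair speaks to a change on this aromatic carbon. Compound 3 is therefore expected to sit close to compound 1, with a 1.0-fold higher number from compound 1 to compound 3 (0.01 log units; within the scatter). The estimate for compound 3 is 18000 nM, with a range from 8000 nM to 40000 nM.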

Compound 3, half-maximal inhibitory concentration: 12900 nM
The estimate for compound 3 lay 1.4-fold (0.14 log units) above the measured number; low and high end bracket the measured number.
By their numbers in this assay, from the lowest: compounds 3, 1 and 2 (each within the scatter of the next).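

Among the compounds shown here, this is the first measured change at this aromatic carbon, ortho to a 1H-benzimidazol-2-yl group. In this assay, chloro in place of methyl gives a 1.4-fold lower number from compound 1 to compound 3 (0.13 log units; within the scatter), so the two groups cannot be told apart here. No available measurement accounts for this result.

Going by these compounds, whether an amine, a carboxylic acid or a methoxy group on this carbon would move the number beyond the scatter remains open. On these data alone, it is also open whether this exchange would read the same with the 2-chlorophenyl group of compound 2 on the far end.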